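Methylcarbamoyl for 1-hydroxy-1-methylethyl: outlook for compound 4

The source may report more compounds than this note shows. Statements on the series, on what has been measured and on what is new or still open speak of the compounds shown alone.

Going by the values given here, compound 1 `COc1cc(OCc2csc(-c3ccc(C(C)(C)O)cc3)n2)c2cc(-c3cn4nc(OC)sc4n3)oc2c1` gives 1.83 h in an ADME assay on microsomes from liver (Homo sapiens) for metabolic stability (a lower number here means that the compound disappears faster, a higher number that the compound lasts longer), the highest of the three numbers so far. Compound 3 `COc1cc(OCc2cccc(-c3ccc(C#N)cn3)c2)c2cc(-c3cn4nc(OC)sc4n3)oc2c1` at 1.57 h lies within the scatter of compound 1, whereas compound 2 `COc1cc(OCc2cccc(-c3ccc(C(F)(F)F)cn3)c2)c2cc(-c3cn4nc(OC)sc4n3)oc2c1` at 0.733 h lies beyond it.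

Compound 4 `CNC(=O)c1ccc(-c2nc(COc3cc(OC)cc4oc(-c5cn6nc(OC)sc6n5)cc34)cs2)cc1` differs from compound 1 by methylcarbamoyl in place of 1-hydroxy-1-methylethyl on an aromatic carbon. Among the compounds with values here, no measured pair makes this exchange. Within the data shown here, the only measured step, a 2.1-fold higher number from compound 2 to compound 3 (0.33 log units; beyond the scatter), concerns a different group on a different arm of the shared core and bears on it only as a gauge of size: one small group swapped gave a modest shift. The direction for compound 4 cannot be read from the series, so a step of no more than that size is expected, a 1.2-fold lower number from compound 1 to compound 4 (0.09 log units; within the scatter). For compound 4 the estimate is 1.5 h, with a range from 0.8 h to 2.8 h.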

Compound 4, half-life: 0.983 h
For compound 4 the middle estimate is 1.5-fold (0.18 log units) above the measured one; measured number inside the range.
By their numbers in this assay, from the lowest: compounds 2, 4, 3 and 1 (each within the scatter of the next, the first and the last beyond it).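

Going by these compounds alone, with a 1.9-fold lower number from compound 1 to compound 4 (0.27 log units; within the scatter) in this assay, this is the first measured exchange at this aromatic carbon, para to a large group, and it does not separate methylcarbamoyl from 1-hydroxy-1-methylethyl. Both groups have the same counted hydrogen-bond donors and acceptors, so this pair does not test a change in those counts. Nothing available explains the result. Open, on these data alone, is whether a carboxylic acid or an amine at this carbon would give a step beyond the scatter. Also open, as far as these compounds go, is how methylcarbamoyl would read on the arm carried by compounds 2 and 3.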